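Swapping a Trihydroxyphenyl for a Dimethylaminophenyl

The compounds below may be only part of what the source reports. "The series", "measured", "known", "first", "only" and "open" are said of these compounds alone.

Three compounds have been measured in a functional assay on DU-145 cells (Homo sapiens) for inhibition, read by trypan blue exclusion, with a stated time of 96 h; on this read-out lower numbers stand for stronger inhibition of growth and higher numbers for weaker inhibition of growth:
compound 1 `Cc1ccc(S/C(=C/c2c[nH]c3ccccc23)C(=O)c2ccc(Br)cc2)cc1` gives 10000 nM
compound 2 `Cc1ccc(S/C(=C/c2ccc(Cl)c(Cl)c2)C(=O)c2ccc(Br)cc2)cc1` gives 50000 nM
compound 3 `Cc1ccc(S/C(=C/c2c(O)cc(O)cc2O)C(=O)c2ccc(Br)cc2)cc1` gives > 100000 nM, which is a limit of the assay and not a number.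

Compound 3 therefore stands at the weak end of the numbers shown: the limit of > 100000 nM in this assay, at which 1 of the 3 values shown sits. The step to it from compound 1 is an at least 10-fold higher number from compound 1 to compound 3 (1.00 log units; beyond the scatter), and from compound 2 it is an at least 2.0-fold higher number from compound 2 to compound 3 (0.30 log units; that floor lies within the scatter); both run toward weaker inhibition of growth once the 2,4,6-trihydroxyphenyl is in place.

Compound 4 `Cc1ccc(S/C(=C/c2ccc(N(C)C)cc2)C(=O)c2ccc(Br)cc2)cc1` is not yet measured. It differs from compound 3 in one place: 4-(dimethylamino)phenyl in place of 2,4,6-trihydroxyphenyl on a double-bonded chain carbon bound to a double-bonded chain carbon. The measured steps that bear on this are the two into compound 3, in each of which an aromatic group without hydroxyls gave way to the 2,4,6-trihydroxyphenyl and inhibition weakened. With a 4-(dimethylamino)phenyl entering instead, the expectation for compound 4 is a step back toward the numbers of the other two compounds, that is an at least 5.0-fold lower number from compound 3 to compound 4 (0.69 log units; beyond the scatter). Compound 4 is estimated at 20000 nM, between 5000 nM and 100000 nM.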

Compound 4, concentration for 50% growth inhibition: > 100000 nM
Compound 4: no number, only a limit; the forecaster's own chance of this, stated with the estimate: 20%; at least 5.0-fold (0.69 log units) between middle value and limit.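

Compound 4 gives > 100000 nM in this assay, which is a limit of the assay and not a number, so a second compound now stands at the weak end: the limit of > 100000 nM in this assay, at which 2 of the 4 values shown sit. Against the 1H-indol-3-yl the change is an at least 10-fold higher number from compound 1 to compound 4 (1.00 log units; beyond the scatter), and against the 3,4-dichlorophenyl it is an at least 2.0-fold higher number from compound 2 to compound 4 (0.30 log units; that floor lies within the scatter); the step between compound 3 and compound 4 cannot be read, both ends being limits. A group with 0 hydrogen-bond donors at this place thus reaches the same limit as the group with 3, so leaving out the hydroxyls did not by itself bring inhibition of growth back into range.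

On these data alone, how far past the limit compound 3 and compound 4 lie stays open, so no order can be given for them. Also open, as far as these compounds go, is whether an unsubstituted phenyl or a 4-methoxyphenyl at this place would return a number.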